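The source may report more compounds than this note shows. Statements on the series, on what has been measured and on what is new or still open speak of the compounds shown alone.

Notes on an in vitro ADME assay on microsomes from liver (Homo sapiens) for metabolic stability, tested at 5 uM; a lower number here means that the compound disappears faster, a higher number that the compound lasts longer. Compound 1 `CC(C)(C)CCn1nc(-c2cccs2)c(O)c(C2=NS(=O)(=O)c3cc(NS(C)(=O)=O)ccc3N2)c1=O` gives > 1 h, which is a limit. Compound 2 `CS(=O)(=O)Nc1ccc2c(c1)S(=O)(=O)N=C(c1c(O)c(-c3cccs3)nn(CCC3CC3)c1=O)N2` gives > 1 h, also a limit. Compound 3 `CS(=O)(=O)Nc1ccc2c(c1)S(=O)(=O)N=C(c1c(O)c(-c3cccs3)nn(CCC3CCC3)c1=O)N2` gives > 1 h, again a limit. The three compounds therefore stand together: the limit of > 1 h in this assay, at which 3 of the 3 values shown sit. Compound 4 `CS(=O)(=O)Nc1ccc2c(c1)S(=O)(=O)N=C(c1c(O)c(-c3cccs3)nn(Cc3ccccc3)c1=O)N2` differs from compound 3 by phenyl in place of cyclobutylmethyl on a saturated chain carbon bound to an aromatic nitrogen. The closest measured changes in this chain are a step that the two limits leave unreadable from compound 1 to compound 2, a step that the two limits leave unreadable from compound 1 to compound 3 and a step that the two limits leave unreadable from compound 2 to compound 3. None of them yields a size, and phenyl at this place has not been measured. In this assay no step beyond the scatter is expected, with no direction favoured: a step that the limit leaves unreadable from compound 3 to compound 4. For compound 4 the estimated half-life is 1.2 h, with an expected range of 0.5 h to 3 h.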

Compound 4, half-life: > 1 h
Compound 4 ended at the assay's limit; the forecaster's own chance of this, stated with the estimate: 60%; the middle value is on the limit's open side.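

In this assay compound 4 gives > 1 h, which is a limit, so its steps from compound 1, compound 2 and compound 3 cannot be read. The four compounds stand together: the limit of > 1 h in this assay, at which 4 of the 4 values shown sit.

As far as these compounds go, the actual half-lives of all four compounds, and any ranking of their groups on the chain, remain open.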